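Methyl in place of carboxy: notes on compound 4

The source may report more compounds than this note shows. Statements on the series, on what has been measured and on what is new or still open speak of the compounds shown alone.

In a functional assay on MCF7 cells (Homo sapiens) for antiproliferative activity, with a stated time of 72 h (on this read-out lower numbers stand for stronger inhibition and higher numbers for weaker inhibition), compound 1 (`COc1cc(OC)c(C(=O)/C=C/c2ccccc2Cl)c(O)c1CN1CCCC1`) gives 3900 nM and compound 2 (`COc1cc(OC)c(C(=O)/C=C/c2ccccc2Cl)c(O)c1CN1CCCCC1`) gives 2600 nM on the shared core. Piperidin-1-yl in place of pyrrolidin-1-yl does not separate the two (a 1.5-fold lower number from compound 1 to compound 2 (0.18 log units; within the scatter)) in this pair. Compound 3 (`COc1cc(OC)c(C(=O)/C=C/c2ccccc2Cl)c(O)c1CN(C)CC(=O)O`) stands at 73200 nM with the highest number of the three, and it is the weakest of them. Both steps leading to it are large (a 19-fold higher number from compound 1 to compound 3 (1.27 log units; beyond the scatter)) and (a 28-fold higher number from compound 2 to compound 3 (1.45 log units; beyond the scatter)) and of similar size.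

Compound 4 (`CCN(C)Cc1c(OC)cc(OC)c(C(=O)/C=C/c2ccccc2Cl)c1O`) has methyl in place of carboxy on a saturated chain carbon bound to an amine nitrogen so that (carboxymethyl)(methyl)amino gives way to ethyl(methyl)amino. Among the compounds with values here, compound 1 and compound 2 also lack the carboxy group, and those two large steps are the only guide, read backwards. No open-chain amine without carboxy has been measured, so the comparison rests on two ring amines. A large step to a lower number is therefore expected in this assay for this change. The expected step is (an 18-fold lower number from compound 3 to compound 4 (1.26 log units; beyond the scatter)) of about the size of the two earlier ones. In this assay the estimate for compound 4 is 4000 nM with an expected range from 1800 nM to 10000 nM around it.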

Compound 4, half-maximal inhibitory concentration: 6800 nM
Estimate against measurement, compound 4: 1.7-fold (0.23 log units) below; measured number inside the range.
By their numbers in this assay, from the lowest: compounds 2, 1 and 4 (each within the scatter of the next, the first and the last beyond it); then compound 3.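

In this assay, within the data shown here, an 11-fold lower number from compound 3 to compound 4 (1.03 log units; beyond the scatter) is the first step in which carboxy leaves while the open-chain amine stays, so the high number of compound 3 goes with carboxy on this saturated chain carbon bound to an amine nitrogen and not with the absence of a ring amine. The ring itself matters little against pyrrolidin-1-yl, with a 1.7-fold higher number from compound 1 to compound 4 (0.24 log units; within the scatter), while against piperidin-1-yl a modest gap remains, with a 2.6-fold higher number from compound 2 to compound 4 (0.42 log units; beyond the scatter), so ethyl(methyl)amino keeps most but not quite all of what the better ring amine gives. No measurement bearing on the reason for these steps is available, and the numbers record only their size.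

The compounds shown leave open whether a methyl ester or a primary amide in place of carboxy would stand with compound 3 or with compound 4, and whether a hydroxy group at this place would behave like carboxy or like methyl. They also do not tell how a longer chain such as propyl in place of ethyl, or a morpholine ring in place of the open-chain amine, would read in this assay.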